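A few compounds are considered here, and "the series" means these few. Any claim that something is new, unique, unknown or untested is made for them only; others in the source may bear on it.

In a physicochemical assay for solubility, read by HPLC, using the shake flask method, in phosphate buffer, with a stated time of 20 h, at pH 6.5 (a higher number here means a more soluble compound, a lower number a less soluble compound), two compounds with the same core have been measured so far. Compound 1 `NCC1CCN(c2nccc3[nH]c(-c4cccc(OC(F)(F)F)c4)nc23)CC1` gives 200000 nM, and compound 2 `CN1CCN(CC2CCN(c3nccc4[nH]c(-c5cccc(OC(F)(F)F)c5)nc34)CC2)CC1` gives 200000 nM, so compound 2 stands level with compound 1 at the digits reported. The next structure, compound 3 `CN1CCN(CC2CCN(c3nccc4[nH]c(-c5cccc(OCCN)c5)nc34)CC2)CC1`, differs from compound 2 in one place: 2-aminoethyl in place of trifluoromethyl on an oxygen on an aromatic ring. Put simply, 2-aminoethyl takes the place of trifluoromethyl on an oxygen on an aromatic ring, turning 3-(trifluoromethoxy)phenyl into 3-(2-aminoethoxy)phenyl. Going by the values given here, only one measured step bears on this, and only indirectly: no change at the digits printed from compound 1 to compound 2 (within the scatter). It stays within the scatter, and it concerns a different place, where 4-methylpiperazin-1-yl replaces amino on a saturated chain carbon. Among the compounds with values here, no measured pair tests the group now being exchanged, so the data give no direction for this change. On the strength of that single step, no change at the digits printed from compound 1 to compound 2 (within the scatter), no step beyond the scatter is expected in this assay. The expected size of the change is no change at the digits printed from compound 2 to compound 3 (within the scatter). The estimate for compound 3 is 200000 nM, with an expected range from 100000 nM to 400000 nM.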

Compound 3, solubility: 200000 nM
For compound 3 middle estimate and measured number coincide at the digits printed; measured number inside the range.
By their numbers in this assay, from the lowest: compounds 1, 2 and 3 (each within the scatter of the next).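

In this assay the exchange on an oxygen on an aromatic ring now has a measured step of its own, which reads no change at the digits printed from compound 2 to compound 3 (within the scatter) and gives this position the direct reading that the earlier step, made at a different place, could not supply. Trifluoromethyl, with 0 hydrogen-bond donors, and 2-aminoethyl, with 1 hydrogen-bond donor, stand level here on the same oxygen, with the rest of compound 2 held constant. Nothing available explains why these two groups read alike.

The compounds shown leave open whether other groups on that oxygen, such as a carboxylic acid, a methyl or a longer chain ending in an amine, would also stand level with these two in this assay or not. They also leave open whether 2-aminoethyl in place of trifluoromethyl would read the same on the oxygen of compound 1, which carries amino rather than 4-methylpiperazin-1-yl on its saturated chain carbon.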